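Swapping Methoxy for Carboxy on the Aromatic Ring

A few compounds are considered here, and "the series" means these few. Any claim that something is new, unique, unknown or untested is made for them only; others in the source may bear on it.

Three compounds share one core and differ only in the aromatic group on the amine nitrogen: compound 1 `C=C1[C@@H](OC(C)=O)C[C@@H]2[C@](C)(COC=O)[C@H](OC(C)=O)CC[C@@]2(C)[C@@H]1C[C@@H](Nc1ccccc1C(=O)O)C1=CCOC1=O`, compound 2 `C=C1[C@@H](OC(C)=O)C[C@@H]2[C@](C)(COC=O)[C@H](OC(C)=O)CC[C@@]2(C)[C@@H]1C[C@@H](Nc1ccccc1F)C1=CCOC1=O` and compound 3 `C=C1[C@@H](OC(C)=O)C[C@@H]2[C@](C)(COC=O)[C@H](OC(C)=O)CC[C@@]2(C)[C@@H]1C[C@@H](Nc1ccc(OC)cc1)C1=CCOC1=O`. In a functional assay on A549 cells (Homo sapiens) for cytotoxicity, read by sulforhodamine B assay (a higher number here means a weaker inhibitor, a lower number a stronger inhibitor), compound 1 gives 45900 nM, compound 2 gives 23600 nM and compound 3 gives 28900 nM. Compound 3 cannot be told apart from its nearest neighbour, with a 1.2-fold higher number from compound 2 to compound 3 (0.09 log units; within the scatter).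

Compound 4 `C=C1[C@@H](OC(C)=O)C[C@@H]2[C@](C)(COC=O)[C@H](OC(C)=O)CC[C@@]2(C)[C@@H]1C[C@@H](Nc1ccc(C(=O)O)cc1)C1=CCOC1=O` has not yet been measured. It differs from compound 3 by carboxy in place of methoxy on an aromatic carbon, para to a large group.

Compound 1 also carries a carboxy group, as its 2-carboxyphenyl, and the data show a 1.6-fold lower number from compound 1 to compound 3 (0.20 log units; within the scatter). The other step from compound 1 is similarly small, with a 1.9-fold lower number from compound 1 to compound 2 (0.29 log units; within the scatter). No step beyond the scatter is therefore expected in this assay, and no firm direction can be given. The estimated step is a 1.2-fold higher number from compound 3 to compound 4 (0.08 log units; within the scatter). Compound 4 is expected near 35000 nM, within an estimated range of 18000 nM to 68000 nM.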

Compound 4, half-maximal inhibitory concentration: > 50000 nM
Compound 4 was reported as a limit; the forecaster's own chance of this, stated with the estimate: 10%; at least 1.4-fold (0.15 log units) between middle value and limit.
By their numbers in this assay, from the lowest: compounds 2, 3 and 1 (each within the scatter of the next). At a limit, above all of these: compound 4.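

In this assay compound 4 is reported only as a limit, not as a number: the limit of > 50000 nM in this assay, at which 1 of the 4 values shown sits.

Putting carboxy in place of methoxy at this position gives an at least 1.7-fold higher number from compound 3 to compound 4 (0.23 log units; that floor lies within the scatter) and exchanging 2-carboxyphenyl for 4-carboxyphenyl gives an at least 1.0-fold higher number from compound 1 to compound 4 (0.03 log units; that floor lies within the scatter) so neither step can yet be told from the scatter. What is new is the single separation beyond the scatter among these compounds, an at least 2.1-fold higher number from compound 2 to compound 4 (0.32 log units; beyond the scatter) and this is a change of the whole aromatic group, not of one substituent at this position.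

Going by these compounds, how far the true number of compound 4 lies past the limit stays open, and with it the real size of the step from methoxy to carboxy. Also open, on these data alone, is whether a methyl ester or an amide in place of the carboxy group would sit with compound 3 or with compound 4.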